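The source may report more compounds than this note shows. Statements on the series, on what has been measured and on what is new or still open speak of the compounds shown alone.

Measured in a functional assay on A549 cells (Homo sapiens) for antiproliferative activity, read by sulforhodamine B assay, with a stated time of 3 days; on this read-out lower numbers stand for stronger inhibition of growth and higher numbers for weaker inhibition of growth:
- compound 1 `O=C(Nc1ccccn1)c1cccc(Nc2ncc(F)c(Nc3ccc(F)cc3)n2)c1`: 15300 nM
- compound 2 `O=C(Nc1ccc(C(F)(F)F)cc1)c1cccc(Nc2ncc(F)c(Nc3ccc(F)cc3)n2)c1`: > 10000 nM
- compound 3 `COc1ccc(NC(=O)c2cccc(Nc3ncc(F)c(Nc4ccc(F)cc4)n3)c2)cc1`: 11000 nM

Among the measured compounds shown here, compound 3 and compound 1 are the only two with readable numbers, and a 1.4-fold lower number from compound 1 to compound 3 (0.14 log units; within the scatter) puts them level with each other. The entry for compound 2 is a limit and not a number. That limit leaves no size to read in a step that the limit leaves unreadable from compound 1 to compound 2 or in a step that the limit leaves unreadable from compound 2 to compound 3.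

Compound 4 `O=C(c1cccc(Nc2ncc(F)c(Nc3ccc(F)cc3)n2)c1)N1CCCCC1` keeps the shared core of compound 3 and changes the group on the carbonyl carbon: piperidin-1-yl in place of (4-methoxyphenyl)amino on a carbonyl carbon. For the measured compounds named here, no measured step brings in a non-aromatic ring at this place, so the expectation rests on one comparison. Going by the values given here, the only readable swap of the group on the amide nitrogen, a 1.4-fold lower number from compound 1 to compound 3 (0.14 log units; within the scatter), stayed within the scatter. No step beyond the scatter is therefore expected in this assay, and growth inhibition should stay weak. The expected change is a 1.4-fold higher number from compound 3 to compound 4 (0.13 log units; within the scatter). Compound 4 could also be reported only as a limit, as compound 2 was. For compound 4 the estimated value is 15000 nM, with an expected range from 6000 nM to 40000 nM.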

Compound 4, concentration for 50% growth inhibition: 13200 nM
Estimate against measurement, compound 4: 1.1-fold (0.06 log units) above; measured number inside the range.
By their numbers in this assay, from the lowest: compounds 3, 4 and 1 (each within the scatter of the next).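

In this assay, the (4-methoxyphenyl)amino group on the carbonyl carbon gives way to piperidin-1-yl, a non-aromatic ring with 0 hydrogen-bond donors, and the result is a 1.2-fold higher number from compound 3 to compound 4 (0.08 log units; within the scatter). Measured against the pyridin-2-yl amide, the same ring gives a 1.2-fold lower number from compound 1 to compound 4 (0.06 log units; within the scatter), so neither the aromatic ring nor the amide hydrogen is needed at this place to keep the level shown by the earlier amides. The steps that involve compound 2 cannot be read, since its entry is a limit and not a number: the limit of > 10000 nM in this assay, at which 1 of the 4 values shown sits.

The compounds shown leave open whether any group on this carbonyl carbon can move the number beyond the scatter. A morpholin-4-yl or piperazin-1-yl ring, or an open chain such as diethylamino, would test this.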